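The compounds below may be only part of what the source reports. "The series", "measured", "known", "first", "only" and "open" are said of these compounds alone.

Within the data shown here, compound 2 `COc1ccc(C(=O)/C=C/c2cc(-c3ccc(OC)c(OC)c3)n3nc(-c4ccccc4)cc3n2)cc1` gives the highest of the two numbers so far in a functional assay on MDA-MB-231 cells (Homo sapiens) for antiproliferative activity, read by MTT assay, with a stated time of 24 h (a lower number here means a stronger inhibitor, a higher number a weaker inhibitor), at 13900 nM; compound 1 `COc1ccc(-c2cc(/C=C/C(=O)c3cc(OC)c(OC)c(OC)c3)nc3cc(-c4ccccc4)nn23)cc1OC` gives 4700 nM in this assay. Among the measured compounds shown here, the one measured step between them, a 3.0-fold higher number from compound 1 to compound 2 (0.47 log units; beyond the scatter), came with a 4-methoxyphenyl in place of 3,4,5-trimethoxyphenyl on the carbonyl carbon. Compound 3 `COc1ccc(C(=O)/C=C/c2cc(-c3ccc(OC)c(OC)c3)n3nc(-c4ccccc4)cc3n2)cc1OC` differs from compound 2 by methoxy in place of hydrogen on an aromatic carbon, which returns part of what that step removed. A modest fall in the number is therefore expected, a 1.9-fold lower number from compound 2 to compound 3 (0.27 log units; within the scatter), smaller than the whole of the earlier step. Compound 3 is estimated at 7500 nM, within a range of 3500 nM to 15000 nM.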

Compound 3, half-maximal inhibitory concentration: 2600 nM
Beside the measured number, compound 3's estimate is 2.9-fold (0.46 log units) above it, outside the stated range (below it).
By their numbers in this assay, from the lowest: compounds 3 and 1 (each within the scatter of the next); then compound 2.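

Going from 4-methoxyphenyl to 3,4-dimethoxyphenyl on the carbonyl gives a 5.3-fold lower number from compound 2 to compound 3 (0.73 log units; beyond the scatter) in this assay, so this one methoxy, ortho to a methoxy group, is enough to recover the loss seen with the 4-methoxyphenyl. The further methoxy of the 3,4,5-trimethoxyphenyl group does not separate the two compounds, with a 1.8-fold lower number from compound 1 to compound 3 (0.26 log units; within the scatter) on replacing it by hydrogen. Going by these compounds, whether a hydroxy group, a fluorine atom or an ethoxy group would serve in the same place remains open, as does a 3-methoxyphenyl group. No measurement shown here accounts for the effect of this methoxy.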